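Inverting One Stereocentre Where Every Value Is a Limit

The source may hold more compounds than are shown below. What is called first, only, known or untested is meant among the compounds shown, and "the series" means these compounds.

Measured in a functional assay (ileum) for inhibition, with Cavia porcellus as the target; on this read-out lower numbers stand for an effect already at smaller amounts and higher numbers for an effect only at larger amounts of compound:
Compound 1, `C[C@@H](NC1=NS(=O)(=O)c2cccnc2N1)C1CCCCC1`: > 300 uM, a limit of the assay.
Compound 2, `O=S1(=O)N=C(NCc2ccccc2)Nc2ncccc21`: > 300 uM, a limit of the assay.
Compound 3, `C[C@H](NC1=NS(=O)(=O)c2cccnc2N1)c1ccccc1`: > 300 uM, a limit of the assay.

Compound 3 stands where all the others stand: at the limit of > 300 uM in this assay, at which 3 of the 3 values shown sit. No number is known for compound 3, only a limit, and the same holds for the two further values shown. For the measured compounds named here, the one step that can be drawn between measured compounds, a step that the two limits leave unreadable from compound 2 to compound 3, is the addition of a methyl in place of hydrogen on a saturated chain carbon bound to an amine nitrogen and an aromatic carbon, and it remains unreadable because both ends sit at the limit of > 300 uM in this assay, at which 3 of the 3 values shown sit.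

Compound 4, `C[C@@H](NC1=NS(=O)(=O)c2cccnc2N1)c1ccccc1`, is the mirror partner of compound 3: the two compounds have the same atoms and bonds and differ only in configuration as drawn: 1 of 1 stereo elements differ; a stereocentre at a saturated chain carbon is drawn S in compound 3 and R in compound 4. Going by the values given here, no measured step concerns a change of configuration alone, and the only step available, from compound 2 to compound 3, carries no readable size. Nothing therefore points to compound 4 leaving the limit, and the expectation for compound 4 in this assay is a step of a number no higher from compound 3 to compound 4 (the limit leaves the size open), that is, no step beyond the scatter. Compound 4 is accordingly estimated at 300 uM, with a range from 100 uM to 1000 uM, most likely reported again only as a limit.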

Compound 4, concentration for half-maximal effect: > 300 uM
Compound 4: only a limit was reported; the forecaster's own chance of this, stated with the estimate: 85%; the middle value sits exactly at the limit.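

In this assay compound 4 gives > 300 uM, again a limit of the assay and not a number. No size can be read for the steps joining compound 4 to compound 1, compound 2 and compound 3. The compounds shown leave open whether inverting the stereocentre changes the effect, and at what concentration any of them would act.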